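The source may report more compounds than this note shows. Statements on the series, on what has been measured and on what is new or still open speak of the compounds shown alone.

Compound 2, `C[C@H]1CC[C@@H]2[C@@H](OC(=O)[C@]23CC(c2ccccc2Br)=NO3)[C@]2(C)C(=O)C=C[C@@]12O`, gives 2.22 in a physicochemical assay for lipophilicity (on this read-out lower numbers stand for lower lipophilicity and higher numbers for higher lipophilicity), the highest of the three numbers. Compound 1, `COc1ccc(C2=NO[C@]3(C2)C(=O)O[C@@H]2[C@H]3CC[C@H](C)[C@]3(O)C=CC(=O)[C@@]23C)cc1`, gives 1.47, and the step of a number 0.75 log units higher from compound 1 to compound 2 (beyond the scatter) lies beyond the scatter. Compound 3, `C[C@H]1CC[C@@H]2[C@@H](OC(=O)[C@]23CC(c2ccccc2[N+](=O)[O-])=NO3)[C@]2(C)C(=O)C=C[C@@]12O`, gives 1.37, and the step of a number 0.85 log units lower from compound 2 to compound 3 (beyond the scatter) is also beyond the scatter. Compound 4, `C[C@H]1CC[C@@H]2[C@@H](OC(=O)[C@]23CC(c2ccc(F)cc2)=NO3)[C@]2(C)C(=O)C=C[C@@]12O`, differs from compound 2 in one place: 4-fluorophenyl in place of 2-bromophenyl on a carbon with a double bond to nitrogen. Going by the values given here, no measured step exchanges bromine for fluorine, so the two steps that touch compound 2 only bracket the question: replacing the 2-bromophenyl has, in both cases, brought the number down. Compound 4 is therefore expected to sit below compound 2, with an estimated step of a number 0.47 log units lower from compound 2 to compound 4 (beyond the scatter). The estimate for compound 4 is 1.75, between 1.4 and 2.1.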

Compound 4, partition coefficient: 1.58
Compound 4: middle estimate off by 0.17 log units, on the high side; the measured number falls inside the stated range.
By their numbers in this assay, from the lowest: compounds 3, 1 and 4 (each within the scatter of the next); then compound 2.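

In this assay, the step of a number 0.64 log units lower from compound 2 to compound 4 (beyond the scatter) shows that compound 2 stands apart from a third group at this carbon, not only from the 4-methoxyphenyl and the 2-nitrophenyl. The steps of a number 0.21 log units higher from compound 3 to compound 4 (within the scatter) and a number 0.11 log units higher from compound 1 to compound 4 (within the scatter) both stay within the scatter, so the 4-fluorophenyl does not separate from those two groups here. No measured evidence accounts for this result. Going by these compounds, whether the number follows the bromine or its place on the ring stays open, as does what an amine or a carboxylic acid on the phenyl ring would give.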